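This account rests on a few compounds, and the source may have more. Where it says the series, first, only, none or still open, it means among the compounds named here.

Compound 2, `Cn1ccc2c(Oc3ccc(NC(=O)c4nn(-c5ccc(Cl)c(C(F)(F)F)c5)ccc4=O)cc3)ccnc21`, gives 15200 nM in a functional assay on MCF7 cells (Homo sapiens) for cytotoxicity, read by MTT assay, with a stated time of 72 h (a higher number here means a weaker inhibitor, a lower number a stronger inhibitor), which is the lowest of the two numbers recorded so far. Its nearest neighbour is compound 1, `Cn1ccc2c(Oc3ccc(NC(=O)c4nn(-c5ccccc5)ccc4=O)cc3)ccnc21`, which gives 45200 nM in this assay. Among the compounds with values here, the only measured step, a 3.0-fold lower number from compound 1 to compound 2 (0.47 log units; beyond the scatter), was modest and concerned the group carried on the aromatic nitrogen, not the ring bearing the amide.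

Compound 3, `Cn1ccc2c(Oc3ccc(NC(=O)c4nn(-c5ccc(Cl)c(C(F)(F)F)c5)ccc4=O)cc3F)ccnc21`, differs from compound 2 by fluoro in place of hydrogen on an aromatic carbon. Within the data shown here, no measured step touches this position, so nothing in the data shows how this assay responds to a change there; the one recorded step cannot be carried over to it. A single fluorine for hydrogen is therefore expected to move the number by no more than the scatter, in either direction, and the expected step of a 1.2-fold lower number from compound 2 to compound 3 (0.07 log units; within the scatter) is set near zero. Compound 3 is thus estimated at 13000 nM, with a range from 5000 nM to 35000 nM.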

Compound 3, half-maximal inhibitory concentration: 18400 nM
Compound 3: the middle estimate sits 1.4-fold (0.15 log units) below what was measured, within the range that was stated.
By their numbers in this assay, from the lowest: compounds 2 and 3 (each within the scatter of the next); then compound 1.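

Fluoro in place of hydrogen on this aromatic carbon, ortho to a large group and meta to a large group, now has a reading of its own: in this assay the step of a 1.2-fold higher number from compound 2 to compound 3 (0.08 log units; within the scatter) means that compound 2 and compound 3 cannot be told apart. The earlier compounds shown here spoke only to the group on the aromatic nitrogen, whereas this pair shows that a single fluorine here, with 4-chloro-3-(trifluoromethyl)phenyl held on that nitrogen, has no effect beyond the scatter. Nothing measured here offers an explanation for this result.

Going by these compounds, whether chloro, methoxy or an amine on this same carbon would shift the number remains open. So does whether fluoro would behave the same way with plain phenyl on the aromatic nitrogen.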